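The source may hold more compounds than are shown below. What is called first, only, known or untested is meant among the compounds shown, and "the series" means these compounds.

Of the compounds shown here, three have numbers so far in a functional assay on COLO 205 cells (Homo sapiens) for inhibition, read by sulforhodamine B assay, with a stated time of 48 h, tested at 50 uM; on this read-out higher numbers stand for more inhibition of growth at the one concentration tested and lower numbers for less inhibition of growth: compound 1 (`COc1cc(/C=C/C(=O)/C=C/c2cccc3ccccc23)ccc1OCc1cn(CCOc2cc(=O)oc3ccccc23)nn1`) gives 85%, compound 2 (`COc1cc(/C=C/C(=O)/C=C/c2cccc3ccccc23)ccc1OCc1cn(CCCOc2cc(=O)oc3ccccc23)nn1`) gives 64% and compound 3 (`COc1cccc(/C=C/C(=O)/C=C/c2ccc(OCc3cn(CCCCOc4cc(=O)oc5ccccc45)nn3)c(OC)c2)c1`) gives 46%. Compound 2 stands second of the three, beyond the scatter from both the higher and the lower value. Compound 4 (`COc1cc(/C=C/C(=O)/C=C/c2cccs2)ccc1OCc1cn(CCCOc2cc(=O)oc3ccccc23)nn1`) departs from compound 2 by one change: thiophen-2-yl in place of naphthalen-1-yl on a double-bonded chain carbon bound to a double-bonded chain carbon. The swap sits on a double-bonded chain carbon bound to a double-bonded chain carbon. Going by the values given here, no measured pair isolates this change, so the data give no direct guide to it. In this assay, no step beyond the scatter is expected, with a slight lean downward. The estimated step is a number 4 percentage points lower from compound 2 to compound 4 (within the scatter). For compound 4 the expected value is 60%, with an estimated range of 40% to 80%.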

Compound 4, percent growth inhibition at one concentration: 55%
For compound 4 the middle estimate is 5 percentage points above the measured one; measured number inside the range.
By their numbers in this assay, from the lowest: compounds 3, 4 and 2 (each within the scatter of the next, the first and the last beyond it); then compound 1.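

In this assay, going by these compounds alone, the first pair at this position gives a number 9 percentage points lower from compound 2 to compound 4 (within the scatter), with thiophen-2-yl in place of naphthalen-1-yl on a double-bonded chain carbon bound to a double-bonded chain carbon. In this one pair, 10 heavy atoms and 2 six-membered aromatic rings give way to 5 heavy atoms and one five-membered aromatic ring with 1 hetero atom, and the step stays within the scatter. No available evidence bears on the reason for this result.

Going by these compounds, whether a carboxylic acid or an amine at this place would also stay within the scatter remains open. So does whether the same swap would behave alike on the chain of compound 1.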